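Isopropoxy on the Benzyl Ring of a Dimethylanilide

A few compounds are considered here, and "the series" means these few. Any claim that something is new, unique, unknown or untested is made for them only; others in the source may bear on it.

In an assay on membranes from HEK293 cells for displacement of a labelled ligand from Translocator protein (Homo sapiens), read by scintillation counting, with a stated time of 90 min (a lower number here means a stronger inhibitor, a higher number a weaker inhibitor), two compounds have been measured so far. Compound 1 `C#CCN(C)C(=O)c1nc2ccccc2n1Cc1ccc(Cl)cc1` gives > 10000 nM, which is a limit of the assay rather than a number. Among the measured compounds shown here, compound 2 `CC(=O)N(Cc1ccccc1)c1cc(C)cc(C)c1` gives 276 nM, the only numerical value in the set, so it stands alone as the single point of reference. Compound 3 `CC(=O)N(Cc1ccc(OC(C)C)cc1)c1cc(C)cc(C)c1` has not yet been measured. It differs from compound 2 by isopropoxy in place of hydrogen on an aromatic carbon. For the measured compounds named here, no measured step connects the two compounds, so the size of the change in this assay can only be anticipated. The expected step from compound 2 to compound 3 is a 1.3-fold lower number from compound 2 to compound 3 (0.10 log units; within the scatter), a shift no larger than the usual scatter in either direction. On that basis compound 3 is estimated at 220 nM in this assay, with a range from 60 nM to 800 nM.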

Compound 3, inhibition constant: 823 nM
The estimate for compound 3 lay 3.7-fold (0.57 log units) below the measured number; the measured number lies above the stated range.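

Isopropoxy on an aromatic carbon of the six-membered aromatic ring, para to a large group, is the first change at this position that can be read in this assay, and it gives a 3.0-fold higher number from compound 2 to compound 3 (0.47 log units; beyond the scatter) in a step that is modest but beyond the scatter. The position therefore responds to substitution, and the response here is a weaker inhibitor, although compound 3 still gives a measured number, 823 nM, and not a limit. Nothing in the data shown gives a reason for this rise.

As far as these compounds go, whether methoxy, fluorine, an amine or a carboxylic acid at the same place would move the number in the same direction remains open. A single step also cannot tell whether isopropoxy would have the same effect on another carbon of this ring.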